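The source may hold more compounds than are shown below. What is called first, only, known or untested is meant among the compounds shown, and "the series" means these compounds.

In a physicochemical assay for solubility, measured as thermodynamic solubility, at pH 7.4 (on this read-out higher numbers stand for higher solubility and lower numbers for lower solubility), compound 1 `O=c1ccoc2cc(C#Cc3ccccc3)ccc12` gives < 1000 nM as a limit of the assay, not a number. Among the measured compounds shown here, compound 2 `COC(=O)N1CCOc2cc(COc3ccccc3)cnc21` gives > 520000 nM as a limit too, so it stands without an exact number, as does the only other compound read so far. Compound 3 `CC(=O)N1CCOc2cc(COc3ccccc3)cnc21` has methyl in place of methoxy on a carbonyl carbon and otherwise keeps the structure of compound 2. For the measured compounds named here, no measured pair in this assay shows what this change does, so the expectation rests on compound 2 alone, with its limit of > 520000 nM as the only anchor. The estimated step of an at least 1.1-fold lower number from compound 2 to compound 3 (0.06 log units; that floor lies within the scatter) is expected to be small and, if anything, downward, and the assay may again report only a limit. For compound 3 the expected value in this assay is 450000 nM with 120000 nM to 800000 nM as the estimated range.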

Compound 3, solubility: 40000 nM
The estimate for compound 3 lay 11-fold (1.05 log units) above the measured number; measured number outside the range, below it.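

Methyl in place of methoxy on a carbonyl carbon, whose other neighbours are amide-type nitrogen in a ring, gives an at least 13-fold lower number from compound 2 to compound 3 (1.11 log units; beyond the scatter) in this assay. Among the compounds shown here, this is the first step that can be read, and it shows that this position is not indifferent: a single change here, with the rest of the structure kept, moves the read-out beyond the scatter. The step gives only a minimum size, since compound 2 stands at a limit of the assay and not at a number: the limit of > 520000 nM in this assay, at which 1 of the 3 values shown sits.

As far as these compounds go, whether a longer chain such as ethoxy, or an amine such as dimethylamino, on this carbonyl carbon would read closer to compound 2 or to compound 3 remains open. Also open, from the compounds shown here alone, is whether the same change would give a step of similar size on a different core.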